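A Smaller Amine at a Second Place on the Core

This account rests on a few compounds, and the source may have more. Where it says the series, first, only, none or still open, it means among the compounds named here.

Three compounds share a core carrying a phenylsulfonyl group and differ in an amine attached to that core. Compound 1, `O=S(=O)(c1ccccc1)n1cc(N2CCCCC2)c2ccccc21`, bears piperidin-1-yl; in an assay on isolated protein for displacement of a labelled ligand from 5-hydroxytryptamine receptor 6 (Homo sapiens), read by scintillation counting, with a stated time of 1 h (a higher number here means a weaker inhibitor, a lower number a stronger inhibitor), compound 1 gives 219 nM. Compound 2, `CN(C)c1cn(S(=O)(=O)c2ccccc2)c2ccccc12`, carries dimethylamino at the same place, and in this assay compound 2 gives 474 nM. The change between them is dimethylamino in place of piperidin-1-yl on an aromatic carbon, and it produced a 2.2-fold higher number from compound 1 to compound 2 (0.34 log units; beyond the scatter).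

Compound 3, `O=S(=O)(c1ccccc1)n1ccc2ccc(N3CCCCC3)cc21`, has the same atoms as compound 1 joined differently; the difference between the two cores is not broken down here. In this assay compound 3 gives 403 nM, which sits within the scatter of both compound 1 and compound 2, so no order among the three can be stated.

Compound 4, `CN(C)c1ccc2ccn(S(=O)(=O)c3ccccc3)c2c1`, is not yet measured. It stands to compound 3 as compound 2 stands to compound 1: the change is dimethylamino in place of piperidin-1-yl on an aromatic carbon. The place differs, though: in the earlier pair the amine sits on a five-membered aromatic ring with 1 nitrogen, two ring bonds from the ring nitrogen, whereas here it sits on a six-membered aromatic ring of carbon only, meta to a fused ring and para to a fused ring. It is therefore the same kind of change, not the same change.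

The expectation rests on the only comparable step shown, a 2.2-fold higher number from compound 1 to compound 2 (0.34 log units; beyond the scatter), and on the value of compound 3, 403 nM. Compound 4 is expected to give 850 nM, within an estimated range from 350 nM to 2000 nM. The step thus expected is a 2.1-fold higher number from compound 3 to compound 4 (0.32 log units; beyond the scatter).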

Compound 4, inhibition constant: 211 nM
Compound 4: middle estimate off by 4.0-fold (0.61 log units), on the high side, outside the stated range (below it).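

On the core of compound 3, putting dimethylamino in place of piperidin-1-yl in this assay gives a 1.9-fold lower number from compound 3 to compound 4 (0.28 log units; within the scatter), so this pair cannot be placed in any order, and the change has no readable effect on this core. The same exchange therefore cannot be assumed to do the same thing on both cores, since the two steps differ by more than the scatter allows: the same change on two cores in this assay, a 2.2-fold higher number (0.34 log units; beyond the scatter) from compound 1 to compound 2 and a 1.9-fold lower number (0.28 log units; within the scatter) from compound 3 to compound 4, 4.1-fold (0.62 log units) apart, beyond the scatter of two such steps. This shows that the step seen on the core of compound 1 did not carry over to the core of compound 3, but it does not show why, because the two pairs differ both in the core and in where the amine sits, and these two differences cannot be separated here, nor can two pairs give a rule for any further core.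

The compounds shown leave open whether another amine, such as pyrrolidin-1-yl or morpholin-4-yl, would follow the same split between the two places or would read alike on both. Among these compounds, they also leave open whether a ring amine and an open-chain amine differ at all on the core of compound 3, given that the one pair tested there stays within the scatter.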